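The compounds below may be only part of what the source reports. "The series", "measured", "known", "first", "only" and "open" are said of these compounds alone.

Compound 1 `CNC(=O)c1cc(Oc2ccc(NC(=O)c3cc4cccnc4n(-c4ccc(Br)cc4F)c3=O)cc2)ccn1`: 1950 nM
Compound 2 `CNC(=O)c1cc(Oc2ccc(NC(=O)c3cc4cccnc4n(-c4ccc(C(F)(F)F)cc4Cl)c3=O)cc2)ccn1`: 3190 nM
Compound 3 `CCNC(=O)c1cc(Oc2ccc(NC(=O)c3cc4cccnc4n(-c4ccccc4)c3=O)cc2)ccn1`: 220 nM

In a functional assay on HT-29 cells (Homo sapiens) for antiproliferative activity, read by MTT assay, with a stated time of 72 h (a lower number here means a stronger inhibitor, a higher number a weaker inhibitor), compound 3 gives the lowest number of the three, and its gaps to compound 1 and to compound 2 both lie beyond the scatter, so it is the strongest inhibitor measured here. Compound 4 `CCNC(=O)c1cc(Oc2ccc(NC(=O)c3cc4cccnc4n(-c4ccc(F)c(Cl)c4)c3=O)cc2)ccn1` differs from compound 3 in one place: 3-chloro-4-fluorophenyl in place of phenyl on an aromatic nitrogen. Going by the values given here, the only measured single-place step, a 1.6-fold higher number from compound 1 to compound 2 (0.21 log units; within the scatter), exchanges one halogen-bearing phenyl for another on the same aromatic nitrogen and stays within the scatter; it does not compare a bare phenyl with a halogenated one. Compounds 1 and 2 also carry a methyl amide where compound 3 carries an ethyl amide, so their higher numbers cannot be assigned to the halogens alone. The data therefore give little direct guidance. A modest weakening, or no change beyond the scatter, is expected, with the estimated step being a 2.3-fold higher number from compound 3 to compound 4 (0.36 log units; beyond the scatter). Compound 4 is estimated at 500 nM in this assay, within a range of 150 nM to 1700 nM.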

Compound 4, half-maximal inhibitory concentration: 2600 nM
Compound 4: the middle estimate sits 5.2-fold (0.72 log units) below what was measured; the whole stated range lies below it.
By their numbers in this assay, from the lowest: compound 3; then compounds 1, 4 and 2 (each within the scatter of the next).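

In this assay, 3-chloro-4-fluorophenyl in place of phenyl on the aromatic nitrogen gives a 12-fold higher number from compound 3 to compound 4 (1.07 log units; beyond the scatter), so with the ethyl amide held constant, the bare phenyl is clearly preferred to this halogenated ring. This single-place step compares a bare phenyl with a halogen-bearing one directly, which the step of a 1.6-fold higher number from compound 1 to compound 2 (0.21 log units; within the scatter) could not do, as it only exchanged one halogen-bearing phenyl for another. Nothing available here explains why this position responds so strongly.

On these data alone, it remains open whether the chlorine, the fluorine or the two together account for the loss, a question that a 3-chlorophenyl or a 4-fluorophenyl group on the same nitrogen would help to settle. As far as these compounds go, how a non-halogen group on the phenyl, such as a methoxy or an amine, would fare is also open.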